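Side chain swap in a series sitting at its limit

The source may report more compounds than this note shows. Statements on the series, on what has been measured and on what is new or still open speak of the compounds shown alone.

In an ADME assay on RAW264.7 cells (Mus musculus) for cytotoxicity, read by MTT assay, with a stated time of 24 h, in the presence of a further agent that is not named here (on this read-out lower numbers stand for stronger inhibition and higher numbers for weaker inhibition), the values are:
compound 1 `CCCOc1ccc(C(O)C2OC(=O)c3c(OC)cc(OC)cc32)cc1` gives > 40000 nM as a limit
compound 2 `COCCCCOc1ccc(C(O)C2OC(=O)c3c(OC)cc(OC)cc32)cc1` gives > 40000 nM as a limit

Compound 2 stands only at the limit > 40000 nM and has no number. The change to compound 3 `COc1cc(OC)c2c(c1)C(C(O)c1ccc(OCc3ccc(F)cc3)cc1)OC2=O` is 4-fluorophenyl in place of 3-methoxypropyl on a saturated chain carbon bound to an oxygen on an aromatic ring and replaces 4-methoxybutoxy with (4-fluorobenzyl)oxy. Within the data shown here, the one measured step on this chain is a step that the two limits leave unreadable from compound 1 to compound 2 and offers no size to carry over. The step expected in this assay is a number no higher from compound 2 to compound 3 (the limit leaves the size open) with no direction fixed by the data. For compound 3 the estimate is 40000 nM (expected range 15000 nM to 80000 nM), and a further limit is likely.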

Compound 3, half-maximal inhibitory concentration: > 40000 nM
Compound 3: no number, only a limit (the forecaster's own chance of this, stated with the estimate: 70%); the middle value lies on the limit itself.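

No step can be read among compound 1, compound 2 and compound 3, since each value is only a limit: the limit of > 40000 nM in this assay, at which 3 of the 3 values shown sit.

In this assay the compounds shown leave open whether any side chain on the shared core gives a number rather than a limit.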